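Swapping the Pendant Aryl Ring: Compound 3 to Compound 4

A few compounds are considered here, and "the series" means these few. Any claim that something is new, unique, unknown or untested is made for them only; others in the source may bear on it.

Three compounds share one core and have been run in an ADME assay on microsomes from liver (Homo sapiens) for metabolic stability, tested at 2.5 uM; on this read-out lower numbers stand for slow clearance and higher numbers for fast clearance. Compound 1 `O=S(=O)(c1ccc(F)c(F)c1)c1cnc2c(F)cccc2c1-c1ccc(Cl)cc1` gives 0.28 mL/min, compound 2 `COc1ccc(S(=O)(=O)c2cnc3c(F)cccc3c2-c2ccc(Cl)cc2)cc1` gives 1.05 mL/min, and compound 3 `O=S(=O)(c1cccc(F)c1)c1cnc2c(F)cccc2c1-c1ccccc1F` gives 0.21 mL/min. Within the data shown here, the one measured step, a 3.8-fold higher number from compound 1 to compound 2 (0.57 log units; beyond the scatter), concerns the aryl ring on the sulfonyl sulfur only. Compound 3 shows the lowest number of the three; it sits within the scatter of compound 1 and beyond the scatter of compound 2.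

Compound 4 `O=S(=O)(c1cccc(F)c1)c1cnc2c(F)cccc2c1-c1ccc(Cl)cc1` differs from compound 3 in a single place: 4-chlorophenyl in place of 2-fluorophenyl on an aromatic carbon. Among the measured compounds shown here, no measured step alters this ring, so the step between compound 1 and compound 2 does not bear on it directly. What the data do show is that compound 1, which already carries the 4-chlorophenyl group, and compound 3, which carries the 2-fluorophenyl group, lie within the scatter of one another in this assay. On that basis the expected change in this assay is none beyond the scatter. Compound 4 is therefore estimated at 0.25 mL/min, with a range from 0.12 mL/min to 0.5 mL/min. The estimated step of a 1.2-fold higher number from compound 3 to compound 4 (0.08 log units; within the scatter) is expected to stay within the scatter.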

Compound 4, intrinsic clearance in a liver preparation (reported as CLH), per the amount of preparation that the assay uses: 0.62 mL/min
For compound 4 the middle estimate is 2.5-fold (0.39 log units) below the measured one; measured number outside the range, above it.
By their numbers in this assay, from the lowest: compounds 3 and 1 (each within the scatter of the next); then compounds 4 and 2 (each within the scatter of the next).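

In this assay this position proves able to move the number: a 3.0-fold higher number from compound 3 to compound 4 (0.47 log units; beyond the scatter) comes from exchanging 2-fluorophenyl for 4-chlorophenyl on an aromatic carbon of the core, with the 3-fluorophenyl group on the sulfonyl sulfur held constant. With 4-chlorophenyl in place, compound 4 also sharpens the picture at the sulfonyl ring: a 2.2-fold higher number from compound 1 to compound 4 (0.35 log units; beyond the scatter) follows from hydrogen in place of fluoro alone, while a 1.7-fold lower number from compound 2 to compound 4 (0.23 log units; within the scatter) stays within the scatter, so 3-fluorophenyl and 4-methoxyphenyl are not told apart here. Nothing at hand accounts for these steps.

Open, going by these compounds, is whether the step at the pendant ring follows the chlorine or the loss of the fluorine, and a plain phenyl group there would separate the two. Also open, on these data alone, is how a pendant ring bearing an amine or a carboxylic acid would read in this assay on this scale.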